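A few compounds are considered here, and "the series" means these few. Any claim that something is new, unique, unknown or untested is made for them only; others in the source may bear on it.

Compound 3, `COc1ccc(CCOc2ccc(-c3c(C)nc(C)c([C@H](OC(C)(C)C)C(=O)O)c3N3CCC(C)(C)CC3)cc2)cc1`, is one of three compounds tested in a toxicity assay on MT2 cells (Homo sapiens) for cytotoxicity, read by XTT assay, with a stated time of 4 days; a higher number here means that more compound is tolerated, a lower number that less compound is tolerated. In this assay compound 3 gives >= 33500 nM, which is a limit of the assay rather than a number. Compound 1, `Cc1nc(C)c([C@H](OC(C)(C)C)C(=O)O)c(N2CCC(C)(C)CC2)c1-c1ccc(-c2ccccc2)cc1`, gives >= 20000 nM in this assay, again a limit. Compound 2, `Cc1nc(C)c([C@H](OC(C)(C)C)C(=O)O)c(N2CCC(C)(C)CC2)c1-c1ccc(Cc2ccccc2)cc1`, gives >= 20000 nM in this assay, also a limit. With all three values being limits, a step that the two limits leave unreadable from compound 1 to compound 2, a step that the two limits leave unreadable from compound 1 to compound 3 and a step that the two limits leave unreadable from compound 2 to compound 3 cannot be read as sizes: two values sit at the limit of >= 20000 nM in this assay, at which 2 of the 3 values shown sit, and one at the limit of >= 33500 nM in this assay, at which 1 of the 3 values shown sits. Compound 4, `Cc1nc(C)c([C@H](OC(C)(C)C)C(=O)O)c(N2CCC(C)(C)CC2)c1-c1ccc(OCCc2ccc(Cl)cc2)cc1`, carries the change (chloro in place of methoxy on an aromatic carbon). Among the measured compounds shown here, no measured step bears on this change, so no step beyond the scatter is expected in this assay, and the assay will most likely again report only a limit. Compound 4 is estimated at 35000 nM, between 15000 nM and 100000 nM. The step this means, a step that the limit leaves unreadable from compound 3 to compound 4, is expected to stay hidden behind the limit.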

Compound 4, half-maximal cytotoxic concentration: >= 33500 nM
Compound 4: a limit, no number; the forecaster's own chance of this, stated with the estimate: 85%; the middle value is on the limit's open side.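

In this assay compound 4 gives >= 33500 nM, which is a limit and not a number. Among the compounds shown here, no step to compound 4 from compound 1, compound 2 or compound 3 can be read. The compounds shown leave open whether chloro and methoxy differ at all in how much compound the cells tolerate.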